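Chloro to trifluoromethyl on the pendant aryl ring

A few compounds are considered here, and "the series" means these few. Any claim that something is new, unique, unknown or untested is made for them only; others in the source may bear on it.

Compound 1 `O=S(=O)(/C=C/c1ccc(O)c(O)c1)NCc1ccc(Cl)cc1` and compound 2 `O=S(=O)(/C=C/c1ccc(O)c(O)c1)NCc1ccc(C(F)(F)F)cc1` share one core. In a functional assay on BV-2 cells (Mus musculus) for inhibition, read by Griess assay, with stated times of 3 h and 24 h (on this read-out lower numbers stand for stronger inhibition and higher numbers for weaker inhibition), compound 1 gives 13700 nM, and compound 2 gives 12600 nM. The change between them is trifluoromethyl in place of chloro on an aromatic carbon, and the step it made, a 1.1-fold lower number from compound 1 to compound 2 (0.04 log units; within the scatter), is small. Compound 3 `CC(=O)Oc1ccc(/C=C/S(=O)(=O)NCc2ccc(Cl)cc2)cc1OC(C)=O` is built on a second core; in this assay compound 3 gives 11000 nM. The difference between the core of compound 1 and the core of compound 3 is not broken down here; the values of compound 3, compound 2 and compound 1 all lie within the usual scatter of one another, so no order among them is read. Compound 4 `CC(=O)Oc1ccc(/C=C/S(=O)(=O)NCc2ccc(C(F)(F)F)cc2)cc1OC(C)=O` has not yet been measured in this assay. It differs from compound 3 by trifluoromethyl in place of chloro on an aromatic carbon, which is the same change as from compound 1 to compound 2, made at the same place on the ring. Within the data shown here, for compound 4 in this assay a step of a 1.0-fold lower number from compound 3 to compound 4 (0.02 log units; within the scatter) is expected, because a 1.1-fold lower number from compound 1 to compound 2 (0.04 log units; within the scatter) is the only prior instance of this change and it stayed within the scatter. Any number for compound 4 near that of compound 3 would agree with this expectation. Compound 4 is estimated at 10500 nM, with a range from 5500 nM to 20000 nM.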

Compound 4, half-maximal inhibitory concentration: 9300 nM
Compound 4: middle estimate off by 1.1-fold (0.05 log units), on the high side; the measured number falls inside the stated range.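

In this assay, trifluoromethyl in place of chloro on the second core gives a 1.2-fold lower number from compound 3 to compound 4 (0.07 log units; within the scatter), and this step sits alongside the one on the first core: the same change on two cores in this assay, a 1.1-fold lower number (0.04 log units; within the scatter) from compound 1 to compound 2 and a 1.2-fold lower number (0.07 log units; within the scatter) from compound 3 to compound 4, 1.1-fold (0.04 log units) apart, within the scatter of two such steps. On these two pairs the change carries from the core of compound 1 to the core of compound 3 without any readable dependence on the core, and the two numbers of each pair stand within the scatter of each other. Among these compounds, this does not show that the two groups are interchangeable across the series: it rests on only two cores, and since neither step rises above the scatter, the pairs cannot test whether a step of real size would carry over from one core to the other.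

Going by these compounds, the pendant aryl ring here carries only chloro or trifluoromethyl, so it remains open whether a methoxy, an amine or a carboxylic acid at that place would give a step beyond the scatter, and whether such a step would hold on both cores. Also open, on these data alone, is what a longer chain linking that ring to the nitrogen would do, on either the free catechol-type core of compound 1 or the acetate-bearing core of compound 3.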